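Replacing the Chlorophenyl Ring with Pyridine on the Alkyne

This account rests on a few compounds, and the source may have more. Where it says the series, first, only, none or still open, it means among the compounds named here.

Three compounds sharing one core were tested in an assay on CHO cells for displacement of a labelled ligand from prostaglandin D2 receptor 2 (Homo sapiens), read by scintillation counting; on this read-out higher numbers stand for weaker inhibition and lower numbers for stronger inhibition. Compound 1 `N#Cc1ccc(OCC(=O)O)c(C#Cc2ccccc2Cl)c1` gives 24 nM. Compound 2 `O=C(O)COc1ccc(Cl)cc1C#Cc1ccccc1Cl` gives 28 nM, the highest of the three numbers, nearest to compound 1 and furthest from compound 3. Compound 3 `CS(=O)(=O)c1ccc(Cl)c(C#Cc2cc(Cl)ccc2OCC(=O)O)c1` gives 3.5 nM. The step of a 1.2-fold higher number from compound 1 to compound 2 (0.07 log units; within the scatter) alters the core ring, whereas the step of an 8.0-fold lower number from compound 2 to compound 3 (0.90 log units; beyond the scatter) alters the ring carried on the triple-bonded carbon. Compound 4 `O=C(O)COc1ccc(Cl)cc1C#Cc1cccnc1` differs from compound 2 by pyridin-3-yl in place of 2-chlorophenyl on a triple-bonded carbon. Among the measured compounds shown here, no measured step exchanges that whole ring; only the step of an 8.0-fold lower number from compound 2 to compound 3 (0.90 log units; beyond the scatter) shows that this part of the molecule matters to this assay. For compound 4 the expected step is a 2.9-fold higher number from compound 2 to compound 4 (0.46 log units; beyond the scatter), a weakening. The estimate for compound 4 is 80 nM, within 20 nM to 320 nM.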

Compound 4, inhibition constant: 117 nM
Compound 4: middle estimate off by 1.5-fold (0.17 log units), on the low side; low and high end bracket the measured number.
By their numbers in this assay, from the lowest: compound 3; then compounds 1 and 2 (each within the scatter of the next); then compound 4.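

Exchanging the whole ring on the triple-bonded carbon does not leave the number unchanged: in this assay, pyridin-3-yl in place of 2-chlorophenyl gives a 4.2-fold higher number from compound 2 to compound 4 (0.62 log units; beyond the scatter), a weakening. Among the compounds shown here, the earlier steps showed only that adding a group to this ring matters, whereas this one replaces the ring itself. Nothing available here gives a reason for the weakening.

This change both brings in a ring nitrogen and removes the chlorine, and the compounds shown do not separate the two. As far as these compounds go, a plain phenyl ring on the triple-bonded carbon, or a methoxy group on the pyridine ring, remains open.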